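Hydroxymethyl on the Pyridin-2-yl Alkyne: Expected Affinity

A few compounds are considered here, and "the series" means these few. Any claim that something is new, unique, unknown or untested is made for them only; others in the source may bear on it.

Compound 1 `Cc1ccc(-n2nccn2)c(C(=O)N2C[C@H](C#Cc3ccc(CO)nc3)CC[C@H]2C)c1`: 339 nM in an assay on cells for binding affinity to Orexin/Hypocretin receptor type 1 (Homo sapiens), read by radioligand binding; on this read-out lower numbers stand for stronger inhibition and higher numbers for weaker inhibition
Compound 2 `Cc1ccc(-n2nccn2)c(C(=O)N2C[C@H](C#Cc3cnccc3O)CC[C@H]2C)c1`: 866 nM in this assay
Compound 3 `Cc1ccc(-n2nccn2)c(C(=O)N2C[C@H](C#Cc3ccc(F)cn3)CC[C@H]2C)c1`: 1.1 nM in this assay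

Compound 3 holds the lowest number of the three in this assay. Its lead is set by a 310-fold lower number from compound 1 to compound 3 (2.49 log units; beyond the scatter) and by a 790-fold lower number from compound 2 to compound 3 (2.90 log units; beyond the scatter), both large steps, whereas a 2.6-fold higher number from compound 1 to compound 2 (0.41 log units; beyond the scatter) is only modest. Compound 4 `Cc1ccc(-n2nccn2)c(C(=O)N2C[C@H](C#Cc3cc(CO)ccn3)CC[C@H]2C)c1` differs from compound 3 by 4-(hydroxymethyl)pyridin-2-yl in place of 5-fluoropyridin-2-yl on a triple-bonded carbon. Among the measured compounds shown here, no measured pair exchanges exactly these two groups, so the step must be read by analogy. The two relevant steps are a 310-fold lower number from compound 1 to compound 3 (2.49 log units; beyond the scatter) and a 790-fold lower number from compound 2 to compound 3 (2.90 log units; beyond the scatter): in each, a ring carrying an oxygen function lost heavily against the 5-fluoropyridin-2-yl ring, but each of those steps also moved the attachment point of the ring, and compound 4 keeps the pyridin-2-yl attachment of compound 3 while adding the hydroxymethyl group that compound 1 carried. A weakening well beyond the scatter is therefore expected, but smaller than the large steps seen. Compound 4 is expected to give a step of a 14-fold higher number from compound 3 to compound 4 (1.13 log units; beyond the scatter) in this assay. Compound 4 is estimated at 15 nM, within a range from 2 nM to 150 nM.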

Compound 4, inhibition constant: 76 nM
Compound 4: middle estimate off by 5.1-fold (0.70 log units), on the low side, within the range that was stated.
By their numbers in this assay, from the lowest: compound 3; then compound 4; then compound 1; then compound 2.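

In this assay, a 69-fold higher number from compound 3 to compound 4 (1.84 log units; beyond the scatter) shows that a ring with the pyridin-2-yl attachment of compound 3 can still lose much of its affinity when 4-(hydroxymethyl)pyridin-2-yl replaces 5-fluoropyridin-2-yl, so the attachment alone does not preserve the low number. Among the compounds shown here, compound 4 also gives the first comparison between two rings that both carry hydroxymethyl: a 4.5-fold lower number from compound 1 to compound 4 (0.65 log units; beyond the scatter) is only modest, while an 11-fold lower number from compound 2 to compound 4 (1.06 log units; beyond the scatter) is large, so a ring with hydroxymethyl can differ clearly from another, yet neither comes near compound 3 on this read-out. Nothing available explains any of these steps.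

The compounds shown cannot separate the loss of the fluorine from the gain of the hydroxymethyl group, and in the step from compound 1 the ring attachment and the place of the hydroxymethyl group change together. A plain pyridin-2-yl ring, 5-(hydroxymethyl)pyridin-2-yl, or a methoxymethyl or aminomethyl group in place of the hydroxymethyl group would be needed to tell whether the fluorine, the hydroxyl oxygen or its location governs the affinity here.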